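Sugar in place of methyl on the fused core

The source may report more compounds than this note shows. Statements on the series, on what has been measured and on what is new or still open speak of the compounds shown alone.

Three compounds of the series carry the same fused core and differ only in the alkyl chain on the triple bond. Compound 1 `CCCCC#Cc1cc2cn(C)c(=O)nc2o1` reaches only the limit of >= 217000 nM in a functional assay on HEL cells (Homo sapiens) for cytotoxicity; on this read-out lower numbers stand for higher toxicity in this test and higher numbers for lower toxicity in this test. Compound 2 `CCCCCCCCCCC#Cc1cc2cn(C)c(=O)nc2o1` likewise stands at a limit, > 150000 nM. Compound 3 `CCCCCCCCC#Cc1cc2cn(C)c(=O)nc2o1` stops at the limit of > 175000 nM as well. Every value shown is therefore a limit, and the steps a step that the two limits leave unreadable from compound 1 to compound 2, a step that the two limits leave unreadable from compound 1 to compound 3 and a step that the two limits leave unreadable from compound 2 to compound 3 cannot be read; compound 2 stands at one of three limits and is ranked against nothing.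

Compound 4 `CCCCCCCCCCC#Cc1cc2cn([C@@H]3O[C@H](CO)[C@@H](O)[C@H]3O)c(=O)nc2o1` replaces the methyl on the aromatic nitrogen: 3,4-dihydroxy-5-(hydroxymethyl)oxolan-2-yl in place of methyl on an aromatic nitrogen. Going by the values given here, no measured step touches this position; all three measured steps concern the chain and give no size. There is thus no basis for expecting a shift in this assay beyond the scatter, and the expected step of a number no higher from compound 2 to compound 4 (the limit leaves the size open) is set at nothing. Compound 4 is expected to give 150000 nM, within 60000 nM to 400000 nM, most likely again reported as a limit.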

Compound 4, minimum cytotoxic concentration: 12000 nM
The estimate for compound 4 lay 13-fold (1.10 log units) above the measured number; the whole stated range lies above it.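

Going by these compounds alone, replacing methyl with 3,4-dihydroxy-5-(hydroxymethyl)oxolan-2-yl on the aromatic nitrogen gives the first readable step in this assay: an at least 12-fold lower number from compound 2 to compound 4 (1.09 log units; beyond the scatter). The chain steps among the earlier compounds cannot be read, so this position is the only one shown to move the read-out, and compound 4 is the only compound with a number rather than a limit. The full size of the step stays open at its upper end because it starts from a limit: the limit of > 150000 nM in this assay, at which 1 of the 4 values shown sits.

As far as these compounds go, it remains open whether the whole 3,4-dihydroxy-5-(hydroxymethyl)oxolan-2-yl group is needed or whether a plain 2-hydroxyethyl group on that nitrogen would give a similar step. Also open, from the compounds shown here alone, is whether the step holds with the shorter chains of compound 1 and compound 3.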